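Cyclopropyl on the aromatic nitrogen of compound 1

The compounds below may be only part of what the source reports. "The series", "measured", "known", "first", "only" and "open" are said of these compounds alone.

For the measured compounds named here, in a functional assay on A2780 cells (Homo sapiens) for antiproliferative activity, read by MTT assay, with a stated time of 48 h (on this read-out higher numbers stand for weaker inhibition and lower numbers for stronger inhibition), compound 1 `COc1ccc(-c2cc3c(cn2)[nH]c(=O)n3-c2cc(OC)c(OC)c(OC)c2)cc1O` gives 240 nM, the lowest of the three numbers so far. Compound 2 `COc1ccc(-c2cc3c(cn2)[nH]c(=O)n3-c2cc(OC)c(OC)c(OC)c2)cc1N` gives 640 nM, and compound 3 `COc1ccc(-c2cc3c(cn2)[nH]c(=O)n3-c2cc(OC)c(OC)c(OC)c2)cc1C(=O)O` gives 4120 nM. Compound 4 `COc1ccc(-c2cc3c(cn2)n(C2CC2)c(=O)n3-c2cc(OC)c(OC)c(OC)c2)cc1O` is still unmeasured and differs from compound 1 as follows: cyclopropyl in place of hydrogen on an aromatic nitrogen. In words, this is cyclopropyl in place of hydrogen on an aromatic nitrogen.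

All three measured steps concern a group on an aromatic carbon: a 2.7-fold higher number from compound 1 to compound 2 (0.43 log units; beyond the scatter) is modest, a 17-fold higher number from compound 1 to compound 3 (1.23 log units; beyond the scatter) is large and a 6.4-fold higher number from compound 2 to compound 3 (0.81 log units; beyond the scatter) is modest. None of them changes the aromatic nitrogen, so the data hold no direct evidence on the new change. These steps show only how far one change has moved the number in this series, and they give no direction for compound 4. No step beyond the scatter is therefore expected as the central case, but the range is kept wide. The estimated step is a 1.2-fold lower number from compound 1 to compound 4 (0.08 log units; within the scatter). Compound 4 is estimated at 200 nM, with an expected range of 40 nM to 1000 nM.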

Compound 4, half-maximal inhibitory concentration: > 20000 nM
Compound 4 gave a limit, no number; the forecaster's own chance of this, stated with the estimate: 3%; middle value at least 100-fold (2.00 log units) away from the limit.
By their numbers in this assay, from the lowest: compound 1; then compound 2; then compound 3. At a limit, above all of these: compound 4.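

In this assay the step on the aromatic nitrogen is an at least 83-fold higher number from compound 1 to compound 4 (1.92 log units; beyond the scatter), so this position of the shared core, unchanged across compounds 1 to 3, does not accept cyclopropyl in place of hydrogen in this series. Changes to the group on the aromatic carbon moved the number no further than a 17-fold higher number from compound 1 to compound 3 (1.23 log units; beyond the scatter), which leaves the nitrogen as the more sensitive of the two places on the data shown. The reading for compound 4 is a limit of the assay and not a number, so the full size of the step remains unknown: the limit of > 20000 nM in this assay, at which 1 of the 4 values shown sits.

The compounds shown do not tell whether any group on this nitrogen gives such a step or whether it is specific to cyclopropyl. A methyl or an ethyl at the same place would separate these two readings.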